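The compounds below may be only part of what the source reports. "The series", "measured", "known", "first", "only" and "open" are said of these compounds alone.

Measured so far in an assay on membranes from Cerebral cortex for displacement of a labelled ligand from Neuronal acetylcholine receptor; alpha4/beta2 (Rattus norvegicus); a higher number here means a weaker inhibitor, a lower number a stronger inhibitor:
compound 1, `O=C(c1cncc(N2CC3CC(C2)N3)c1)N1CCCc2ccccc21`, 0.196 nM
compound 2, `O=C(Nc1ccccc1F)c1cncc(N2CC3CC(C2)N3)c1`, 0.315 nM

Within the data shown here, compound 2 stands at the higher of the two numbers, with compound 1 as its only neighbour, and the gap between them lies within the usual scatter of this assay, so neither compound can be called the stronger binder on these data. Both are sub-nanomolar inhibitors that share the same core and differ in what hangs off the carbonyl.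

Compound 3, `O=C(Nc1ccc(Cl)cc1)c1cncc(N2CC3CC(C2)N3)c1`, has not yet been measured in this assay. It differs from compound 2 by 4-chlorophenyl in place of 2-fluorophenyl on an amide-type nitrogen. Among the measured compounds shown here, no measured pair shows this exchange, so there is no step on record to lean on; the account rests on compound 2 alone. Since compound 2 gives 0.315 nM and both amide-type compounds sit close together, the step is expected to be modest, a 1.6-fold higher number from compound 2 to compound 3 (0.20 log units; within the scatter), leaning toward a somewhat higher number but quite possibly staying within the scatter. Compound 3 is therefore estimated at 0.5 nM, with a range from 0.15 nM to 2 nM.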

Compound 3, inhibition constant: 0.404 nM
Estimate against measurement, compound 3: 1.2-fold (0.09 log units) above; low and high end bracket the measured number.
By their numbers in this assay, from the lowest: compounds 1, 2 and 3 (each within the scatter of the next, the first and the last beyond it).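

In this assay, among these compounds, the exchange of 2-fluorophenyl for 4-chlorophenyl on an amide-type nitrogen gives the first step on record at this position: a 1.3-fold higher number from compound 2 to compound 3 (0.11 log units; within the scatter). On these data the two groups cannot be told apart, and compound 3 at 0.404 nM remains a sub-nanomolar inhibitor, as compound 2 is at 0.315 nM. Both the halogen and its place on the ring change in this single exchange, so the step cannot separate the two changes, and nothing measured here accounts for the result.

The compounds shown leave open whether this tolerance extends beyond halogen-bearing phenyl groups, such as to an unsubstituted phenyl, a methoxyphenyl or a cyanophenyl. They also leave open what happens when the aromatic ring on the amide-type nitrogen gives way to a cyclohexyl group or a longer alkyl chain, or when a methyl group takes the place of the amide hydrogen.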